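Branched amine in place of pyrrolidine on a fused core

The source may report more compounds than this note shows. Statements on the series, on what has been measured and on what is new or still open speak of the compounds shown alone.

Measured compounds:
compound 1 `Cc1nc(N2CCCC2)c2nnn(-c3ccc(C(C)C)cc3Br)c2n1` — 194 nM
compound 2 `CCCCN(CC)c1nc(C)nc2c1nnn2-c1c(Cl)cc(OC)cc1OC` — 4.4 nM

In an in vitro assay on 293-EBNA cells for binding affinity to corticotropin-releasing factor receptor 1 (Homo sapiens) (a higher number here means a weaker inhibitor, a lower number a stronger inhibitor), compound 1 gives 194 nM, the higher of the two numbers; compound 2 gives 4.4 nM, a lower number, and the gap between these two values lies beyond the scatter. Compound 3 `CCCCC(CCCC)Nc1nc(C)nc2c1nnn2-c1ccc(C(C)C)cc1Br` differs from compound 1 in one place: a group of 10 heavy atoms (9 carbon, 1 nitrogen; no ring) in place of a group of 5 heavy atoms (4 carbon, 1 nitrogen; one five-membered non-aromatic ring with 1 hetero atom), on an aromatic carbon. For the measured compounds named here, no measured pair shows this change. Compound 3 is expected to give a lower number than compound 1, a step of a 7.8-fold lower number from compound 1 to compound 3 (0.89 log units; beyond the scatter) beyond the scatter, because compound 2, which also carries an open-chain amine, gives 4.4 nM. Compound 3 is estimated at 25 nM, within 5 nM to 120 nM.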

Compound 3, inhibition constant: 4.5 nM
Compound 3: the middle estimate sits 5.6-fold (0.74 log units) above what was measured; the whole stated range lies above it.
By their numbers in this assay, from the lowest: compounds 2 and 3 (each within the scatter of the next); then compound 1.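

In this assay, the open-chain amine of compound 3 in place of pyrrolidin-1-yl gives a 43-fold lower number from compound 1 to compound 3 (1.63 log units; beyond the scatter), showing that this position, next to the ring nitrogen, responds strongly to the amine it carries and needs no ring there. The change alters ring, size and hydrogen-bond donor count at once, so this single step cannot separate them. Nothing available here explains the step. Still open, from the compounds shown here alone, is how a piperidin-1-yl ring would compare at this position. Also open, going by these compounds, is whether a shorter open-chain amine, such as a pentan-3-ylamino group, would keep the gain.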